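The source may hold more compounds than are shown below. What is called first, only, known or untested is meant among the compounds shown, and "the series" means these compounds.

Compound 1 `CCCn1c(=O)n(C)c(=O)c2c1ncn2CC(N)=O`: in an assay on Cerebral cortex for binding affinity to adenosine receptor A1 (Cavia porcellus), read by radioligand binding (on this read-out lower numbers stand for stronger inhibition and higher numbers for weaker inhibition), compound 1 gives > 200000 nM, which is a limit of the assay and not a number.
Compound 2 `CCCn1c(=O)n(C)c(=O)c2c1ncn2CC#N`: in this assay compound 2 gives 6600 nM.
Compound 3 `CCCn1c(=O)n(C)c(=O)c2c1ncn2CC(C)=O`: in this assay compound 3 gives 95700 nM.

All three compounds share one core and differ only in the group on a saturated chain carbon bound to an aromatic nitrogen. Of the two actual numbers, compound 3 has the higher one, and the step of a 15-fold higher number from compound 2 to compound 3 (1.16 log units; beyond the scatter) shows that it binds clearly more weakly than compound 2. Compound 1 gives only a limit.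

Compound 4 `CCCn1c(=O)n(C)c(=O)c2c1ncn2CCC(C)=O` has not yet been measured. Its difference from compound 3 is 2-oxopropyl in place of acetyl on a saturated chain carbon bound to an aromatic nitrogen. Going by the values given here, none of the measured steps bears directly on this kind of change: an at least 30-fold lower number from compound 1 to compound 2 (1.48 log units; beyond the scatter) and a 15-fold higher number from compound 2 to compound 3 (1.16 log units; beyond the scatter) exchange one group for another at the same place, and an at least 2.0-fold lower number from compound 1 to compound 3 (0.32 log units; beyond the scatter) alters the group on the carbonyl carbon. They show that the group at this place matters greatly, but give no direction for this particular change. The expected step in this assay is therefore a 1.0-fold higher number from compound 3 to compound 4 (0.02 log units; within the scatter), not beyond the scatter. For compound 4 the estimated value is 100000 nM, with a range from 30000 nM to 350000 nM.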

Compound 4, inhibition constant: 30000 nM
For compound 4 the middle estimate is 3.3-fold (0.52 log units) above the measured one; measured number inside the range.
By their numbers in this assay, from the lowest: compound 2; then compound 4; then compound 3. At a limit, above all of these: compound 1.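

In this assay, moving from acetyl to 2-oxopropyl on a saturated chain carbon bound to an aromatic nitrogen gives a 3.2-fold lower number from compound 3 to compound 4 (0.50 log units; beyond the scatter) and so brings a modest gain, which shows that the length of the chain matters here, not only the kind of group at this place. Even so, the cyano group of compound 2 keeps the lower number, with a 4.5-fold higher number from compound 2 to compound 4 (0.66 log units; beyond the scatter) in the step to the 2-oxopropyl group. Compound 1 gives only a limit of the assay and not a number, so its comparison can be read only as an at least 6.6-fold lower number from compound 1 to compound 4 (0.82 log units; beyond the scatter) and not as an exact size.

On these data alone, whether a still longer chain ending in a carbonyl, or an amine or a carboxylic acid at this place, would lower the number further remains open. Nothing shown here explains why 2-oxopropyl gives a lower number than acetyl.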